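Sulfonyl amine exchange in a urea series

The compounds below may be only part of what the source reports. "The series", "measured", "known", "first", "only" and "open" are said of these compounds alone.

Measured so far:
compound 1 `O=C(NCc1ccncc1)Nc1ccc(S(=O)(=O)N2CC3CCC(C2)O3)cc1` — 279 nM
compound 2 `O=C(NCc1cn[nH]c1)Nc1ccc(S(=O)(=O)c2ccccc2)cc1` — 28 nM
compound 3 `CCOC(=O)c1ccc(NC(=O)NCc2cc[nH]n2)cc1` — 69000 nM

In an assay on isolated protein for activation of Nicotinamide phosphoribosyltransferase (Homo sapiens) (on this read-out higher numbers stand for an effect only at larger amounts of compound and lower numbers for an effect already at smaller amounts), compound 1 gives 279 nM, the second highest of the three numbers. Compound 2 gives 28 nM, a lower number beyond the scatter, and compound 3 gives 69000 nM, far higher. Compound 4 `CN(C1CCCC1)S(=O)(=O)c1ccc(NC(=O)NCc2ccncc2)cc1` is not yet measured; it differs from compound 1 in one place: a group of 7 heavy atoms (6 carbon, 1 nitrogen; one five-membered non-aromatic ring of carbon only) in place of a group of 8 heavy atoms (6 carbon, 1 nitrogen, 1 oxygen; one five-membered non-aromatic ring with 1 hetero atom, one six-membered non-aromatic ring with 2 hetero atoms), on a sulfonyl sulfur. Among the measured compounds shown here, no measured pair shows this change, so the expected step rests on compound 1 alone. The expected step from compound 1 to compound 4 in this assay is a 1.4-fold lower number from compound 1 to compound 4 (0.14 log units; within the scatter), a change not clearly beyond the scatter in either direction. Compound 4 is estimated at 200 nM, within 60 nM to 700 nM.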

Compound 4, half-maximal effective concentration: 123 nM
Estimate against measurement, compound 4: 1.6-fold (0.21 log units) above; the range from low to high includes it.
By their numbers in this assay, from the lowest: compound 2; then compound 4; then compound 1; then compound 3.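

Among the compounds shown here, on the sulfonyl sulfur, cyclopentyl(methyl)amino in place of the group of 8 heavy atoms gives a 2.3-fold lower number from compound 1 to compound 4 (0.36 log units; beyond the scatter) in this assay, the first one-place step. The leaving group carries an oxygen and a hydrogen-bond acceptor and the entering group carries neither, so neither is required at this position for a value in this range. Nothing available bears on the reason for the step.

Open, on these data alone, is how a morpholine or a plain dimethylamino group on the sulfonyl sulfur would compare. Also open, as far as these compounds go, is whether this step holds with another group in place of the pyridinylmethyl urea side.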